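Fluoro-indanylidene acetamides: ethyl versus isopropyl amide

The source may hold more compounds than are shown below. What is called first, only, known or untested is meant among the compounds shown, and "the series" means these compounds.

Compound 1 `CCNC(=O)/C=C1\CCc2ccc(F)cc21` carries an ethylamide on the shared core; in a functional assay on the whole organism with Mus musculus as the target, at a dose of 100 mg/kg by the intraperitoneal route (on this read-out higher numbers stand for more inhibition at the one dose given (going by the name of the read-out) and lower numbers for less inhibition), compound 1 gives 100%. Compound 2 `CC(C)NC(=O)/C=C1\CCc2ccc(F)cc21` differs from compound 1 by methyl in place of hydrogen on a saturated chain carbon bound to an amide-type nitrogen and a saturated chain carbon and in this assay compound 2 gives 100%, so that no change at the digits printed from compound 1 to compound 2 (within the scatter). Compound 3 `CCNC(=O)/C=C1\CCc2c(F)cc(F)cc21` keeps the ethylamide of compound 1 but differs in the core by fluoro in place of hydrogen on an aromatic carbon; in this assay compound 3 gives 67%, and a number 33 percentage points lower from compound 1 to compound 3 (beyond the scatter). Compound 3 thus stands lowest of the three measured numbers, with its steps to compound 1 and compound 2 both beyond the scatter.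

Compound 4 `CC(C)NC(=O)/C=C1\CCc2c(F)cc(F)cc21` is not yet measured in this assay. It differs from compound 3 by methyl in place of hydrogen on a saturated chain carbon bound to an amide-type nitrogen and a saturated chain carbon, which is the same change as from compound 1 to compound 2, at a place that reads word for word the same around it; the two cores differ by the fluoro described above.

For the measured compounds named here, the one measured instance of this change left the number level, though both ends sat at the same high number, so it cannot show whether the methyl raises or lowers the number when the starting point is lower. The expectation for compound 4 is therefore anchored on compound 3 and its 67%, with a step of no change at the digits printed from compound 3 to compound 4 (within the scatter) expected to stay within the scatter, as the earlier step of no change at the digits printed from compound 1 to compound 2 (within the scatter) did. In this assay compound 4 is estimated at 67%, between 45% and 90%.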

Compound 4, a percentage reported as inhibition, in the whole organism at one dose (the size of the read-out at that dose, not a potency): 100%
Compound 4: the middle estimate sits 33 percentage points below what was measured, outside the stated range (above it).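

On the core of compound 3, the ethyl to isopropyl change gives a number 33 percentage points higher from compound 3 to compound 4 (beyond the scatter) in this assay, so the step seen on the core of compound 1 does not carry over to this core at the same size: the same change on two cores in this assay, no change at the digits printed (within the scatter) from compound 1 to compound 2 and a number 33 percentage points higher (beyond the scatter) from compound 3 to compound 4, 33 percentage points apart, beyond the scatter of two such steps

Read the other way, fluoro in place of hydrogen on an aromatic carbon gives no change at the digits printed from compound 2 to compound 4 (within the scatter), so the drop seen with the ethylamide does not carry over to the isopropylamide either: the same change on two cores in this assay, a number 33 percentage points lower (beyond the scatter) from compound 1 to compound 3 and no change at the digits printed (within the scatter) from compound 2 to compound 4, 33 percentage points apart, beyond the scatter of two such steps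

Each change rests on one pair of steps, which shows that the two changes do not add up across these four compounds but gives neither a reason nor a rule for the wider series, and with compound 2 at 100% and compound 4 at 100%, the level step cannot show how the two compounds might differ at another dose.

The compounds shown leave open whether a longer chain such as n-butyl, or a cyclopropyl, in place of the isopropyl would hold the number on the core of compound 3. They also leave open whether chloro in place of the added fluoro would give the same drop with the ethylamide and the same recovery with the isopropylamide.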